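A few compounds are considered here, and "the series" means these few. Any claim that something is new, unique, unknown or untested is made for them only; others in the source may bear on it.

Compounds measured in an assay on isolated protein for inhibition of RAC-beta serine/threonine-protein kinase (Homo sapiens), read by mobility shift assay, tested at 30 uM; a lower number here means less inhibition, a higher number more inhibition at the concentration tested (going by the name of the read-out):

- compound 1, `Nc1n[nH]c2cc(-c3cccs3)[nH]c(=O)c12`: 5%
- compound 2, `CC(C)(C)c1cc2[nH]nc(N)c2c(=O)[nH]1`: 4%
- compound 3, `Cc1cc2nn(-c3ccccc3)c(N)c2c(=O)[nH]1`: 1%

Compound 3 has the lowest of the three numbers, but its gaps to compound 2 and compound 1 are both within the scatter, so all three sit at a similar low level. Compound 4, `COc1ccc(-c2cc3nn(-c4ccccc4)c(N)c3c(=O)[nH]2)cc1`, differs from compound 3 in one place: 4-methoxyphenyl in place of methyl on an aromatic carbon. Within the data shown here, the only measured step that bears on this is a number 1 percentage points lower from compound 1 to compound 2 (within the scatter), where exchanging a ring group for a chain group on a ring carbon left the number essentially unchanged. An aryl group entering in place of a small chain is therefore expected to bring no step beyond the scatter: a number 4 percentage points higher from compound 3 to compound 4 (within the scatter). Compound 4 is estimated at 5%, between -6% and 20%.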

Compound 4, a percentage reported as inhibition, at one concentration (the size of the read-out at that concentration, not a potency): 0%
The estimate for compound 4 lay 5 percentage points above the measured number; the measured number falls inside the stated range.
By their numbers in this assay, from the lowest: compounds 4, 3, 2 and 1 (each within the scatter of the next).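

In this assay, placing 4-methoxyphenyl instead of methyl on the aromatic carbon next to the ring nitrogen gives a number 1 percentage points lower from compound 3 to compound 4 (within the scatter), so compound 3 and compound 4 sit at a similar low level. At this position, then, adding a six-membered aromatic ring and a hydrogen-bond acceptor does not give a step beyond the scatter. Nothing available explains this result. Going by these compounds, whether an amine or a carboxylic acid on this aromatic carbon would give a step beyond the scatter from compound 3 remains open.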